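Toward Compound 4: Octyl in Place of 4-Bromobenzyl

A few compounds are considered here, and "the series" means these few. Any claim that something is new, unique, unknown or untested is made for them only; others in the source may bear on it.

compound 1, `O=C(CN1CCC(Cc2ccccc2)CC1)Nc1ccc(C(=O)/C=C/c2cn(Cc3ccc(Br)cc3)nn2)cc1`: 40000 nM
compound 2, `CCCCCCCCn1cc(/C=C/C(=O)c2ccc(NC(=O)CN3CCN(C(=O)OC(C)(C)C)CC3)cc2)nn1`: 43300 nM
compound 3, `O=C(CN1CCN(c2ccc([N+](=O)[O-])cc2)CC1)Nc1ccc(C(=O)/C=C/c2cn(Cc3ccc(Br)cc3)nn2)cc1`: 45500 nM

Of the compounds shown here, three have been measured in a functional assay on A549 cells (Homo sapiens) for inhibition, read by MTT assay; on this read-out higher numbers stand for weaker inhibition and lower numbers for stronger inhibition. In this assay compound 1 gives 40000 nM, compound 2 gives 43300 nM, and compound 3 gives 45500 nM. Compound 1 stands lowest of the three, but its gaps to compound 2 and to compound 3 both lie within the scatter, so no order can be read among them.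

Compound 4, `CCCCCCCCn1cc(/C=C/C(=O)c2ccc(NC(=O)CN3CCC(Cc4ccccc4)CC3)cc2)nn1`, awaits measurement. It differs from compound 1 by heptyl in place of 4-bromophenyl on a saturated chain carbon bound to an aromatic nitrogen; cut one bond further out, the same difference reads 4-bromobenzyl to octyl. Among the compounds with values here, no measured pair shows this change by itself. Compound 2, which carries the octyl, gives a number within the scatter of compound 1, though the two differ elsewhere as well. The step from compound 1 to compound 4 is therefore expected to stay within the scatter, a 1.1-fold higher number from compound 1 to compound 4 (0.02 log units; within the scatter). Compound 4 is estimated at 42000 nM, with a range from 20000 nM to 85000 nM.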

Compound 4, half-maximal inhibitory concentration: 43800 nM
For compound 4 the middle estimate is 1.0-fold (0.02 log units) below the measured one; the range from low to high includes it.
By their numbers in this assay, from the lowest: compounds 1, 2, 4 and 3 (each within the scatter of the next).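

In this assay, within the data shown here, this pair shows the change by itself for the first time, with a 1.1-fold higher number from compound 1 to compound 4 (0.04 log units; within the scatter) as its step. On a saturated chain carbon bound to an aromatic nitrogen, then, the open heptyl chain can replace 4-bromophenyl, losing both the ring and the bromine, and the number stays within the scatter. Nothing measured here accounts for this result. On these data alone, whether a shorter chain such as butyl, or an octyl chain ending in an amine or a carboxylic acid, would also leave the number within the scatter remains open.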